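Acetate to hydroxyl at the core alcohol: series notes

The compounds below may be only part of what the source reports. "The series", "measured", "known", "first", "only" and "open" are said of these compounds alone.

Measured so far:
compound 1 `C=C1CC[C@@H]2[C@](C)(CO[Si](C)(C)C(C)(C)C)[C@H](OC(C)=O)CC[C@@]2(C)[C@@H]1C/C=C1/C(=O)OC[C@H]1OC(C)=O` — 2.23 uM
compound 2 `C=C1CC[C@@H]2[C@](C)(CO[Si](C)(C)C(C)(C)C)[C@H](O)CC[C@@]2(C)[C@@H]1C/C=C1/C(=O)OC[C@H]1OC(C)=O` — 8.94 uM
compound 3 `C=C1CC[C@@H]2[C@](C)(CO[Si](c3ccccc3)(c3ccccc3)C(C)(C)C)[C@H](OC(C)=O)CC[C@@]2(C)[C@@H]1C/C=C1/C(=O)OC[C@H]1OC(C)=O` — 12.3 uM

Three compounds have a number in a functional assay on Col2 cells (Homo sapiens) for cytotoxicity, read by sulforhodamine B assay; a higher number here means that more compound is needed for the effect, a lower number that less compound is needed. Compound 1 gives 2.23 uM. Compound 2 differs from compound 1 by hydrogen in place of acetyl on an oxygen on a saturated carbon. Compound 2 gives 8.94 uM, which is a 4.0-fold higher number from compound 1 to compound 2 (0.60 log units; beyond the scatter). Compound 3 gives 12.3 uM, the highest of the three numbers; against compound 2 the gap lies within the scatter, against compound 1 beyond it. How the core of compound 3 differs from the core of compound 1 is not broken down here.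

Compound 4 `C=C1CC[C@@H]2[C@](C)(CO[Si](c3ccccc3)(c3ccccc3)C(C)(C)C)[C@H](O)CC[C@@]2(C)[C@@H]1C/C=C1/C(=O)OC[C@H]1OC(C)=O` is not yet measured. It differs from compound 3 by hydrogen in place of acetyl on an oxygen on a saturated carbon, the same change that separates compound 2 from compound 1, at the same place. In this assay, for the measured compounds named here, a step of about a 2.8-fold higher number from compound 3 to compound 4 (0.45 log units; beyond the scatter) from compound 3 to compound 4 is expected, resting on the single earlier case, a 4.0-fold higher number from compound 1 to compound 2 (0.60 log units; beyond the scatter), with wide bounds because only one such step is known and compound 3 already sits at the high end. Compound 4 is therefore estimated at 35 uM, between 12 uM and 100 uM.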

Compound 4, concentration for half-maximal effect: 10.7 uM
The estimate for compound 4 lay 3.3-fold (0.51 log units) above the measured number; the whole stated range lies above it.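

In this assay the change from acetoxy to hydroxy on the core of compound 3 gives a 1.1-fold lower number from compound 3 to compound 4 (0.06 log units; within the scatter), so on this core the step cannot be told apart from the scatter. The change does not carry over at one size between the two cores: the same change on two cores in this assay, a 4.0-fold higher number (0.60 log units; beyond the scatter) from compound 1 to compound 2 and a 1.1-fold lower number (0.06 log units; within the scatter) from compound 3 to compound 4, 4.6-fold (0.66 log units) apart, beyond the scatter of two such steps. The step seen on the core of compound 1 therefore cannot be assumed on another core in this series, but two pairs do not show which feature of the cores sets the outcome, nor what a third core would give.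

Open, from the compounds shown here alone, is whether the dependence on the core would hold for groups other than acetyl, and how a benzoyl group or a longer acyl chain on the same oxygen would compare with acetyl and hydrogen on either core. Also open, going by these compounds, is what a methyl ether at that oxygen would give on each of the two cores.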